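The source may hold more compounds than are shown below. What is called first, only, known or untested is meant among the compounds shown, and "the series" means these compounds.

Working notes on the series. The compounds share the core of compound 1 `N#C/C(=C\c1c(-c2ccccc2)[nH]c2ccccc12)C(=O)c1ccccc1`. In a functional assay on SW-620 cells (Homo sapiens) for inhibition, read by sulforhodamine B assay, with a stated time of 48 h (a lower number here means a stronger inhibitor of growth, a higher number a weaker inhibitor of growth), compound 1 gives 3000 nM. Compound 3 `COc1ccc(-c2[nH]c3ccc(OC)cc3c2/C=C(\C#N)S(=O)(=O)c2ccccc2)cc1`, which carries methoxy groups and a different substituent pattern on the double bond, gives 540 nM in this assay. Compound 2 `O=C(/C(=C\c1c(-c2ccccc2)[nH]c2ccccc12)S(=O)(=O)c1ccccc1)c1ccccc1` gives "not determined" (no result reported) in this assay, so there is no number to place it against compound 1 or compound 3. Compound 4 `CC(=O)/C(=C\c1c(-c2ccccc2)[nH]c2ccccc12)S(=O)(=O)c1ccccc1` differs from compound 2 by methyl in place of phenyl on a carbonyl carbon, benzoyl to acetyl. With no value for compound 2, no direction is read for this step, and no change beyond the scatter is assumed either way; the expectation rests on compound 1 and compound 3 alone. Compound 4 is estimated at 3000 nM, within 700 nM to 13000 nM.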

Compound 4, concentration for 50% growth inhibition: 778 nM
Beside the measured number, compound 4's estimate is 3.9-fold (0.59 log units) above it, and the stated range covers the measured number.
By their numbers in this assay, from the lowest: compounds 3 and 4 (each within the scatter of the next); then compound 1.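

Compound 2 has no number in this assay, so the benzoyl to acetyl step to compound 4 cannot be read. The compounds shown leave open what that change alone does to growth inhibition. No evidence on a cause is available for this result.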